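Adding a nitro group to a weak thione analogue

The source may hold more compounds than are shown below. What is called first, only, known or untested is meant among the compounds shown, and "the series" means these compounds.

Compound 1 `c1ccc(/N=c2\ssnc2-c2ccco2)cc1`: in a functional assay on MCF7 cells (Homo sapiens) for antiproliferative activity, read by MTT assay, with a stated time of 72 h (on this read-out lower numbers stand for stronger inhibition of growth and higher numbers for weaker inhibition of growth), compound 1 gives 10000 nM.
Compound 2 `CCOC(=O)c1nss/c1=N\c1ccccc1`: in this assay compound 2 gives > 10000 nM, a limit of the assay rather than a number.
Compound 3 `S=c1ssnc1-c1ccccc1`: in this assay compound 3 gives > 10000 nM, again a limit rather than a number.

Compound 3 thus sits at the limit (the limit of > 10000 nM in this assay, at which 2 of the 3 values shown sit), so its true value is not known. Within the data shown here, the only measured step, a number no lower from compound 1 to compound 2 (the limit leaves the size open), changes a different part of the shared core and its size cannot be read, so it says little about the present change. Compound 4 `O=[N+]([O-])c1ccc(-c2nssc2=S)cc1` differs from compound 3 by nitro in place of hydrogen on an aromatic carbon. With no comparable step shown, no shift beyond the scatter is expected, and the step of a number no higher from compound 3 to compound 4 (the limit leaves the size open) is estimated as small. Compound 4 is expected to give 10000 nM, within 3000 nM to 30000 nM, with a real chance that only a limit is reported.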

Compound 4, concentration for 50% growth inhibition: > 10000 nM
Compound 4 gave a limit, no number; the forecaster's own chance of this, stated with the estimate: 55%; the middle value sits exactly at the limit.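

Compound 3 and compound 4 both give only a limit in this assay, so the step between them cannot be read: the limit of > 10000 nM in this assay, at which 3 of the 4 values shown sit. Going by these compounds, whether nitro in place of hydrogen changes growth inhibition at all stays open.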